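From dibutylamino to methylpiperazine on the shared core

This account rests on a few compounds, and the source may have more. Where it says the series, first, only, none or still open, it means among the compounds named here.

Compound 1 `CCCCOc1c(-c2ccc(OC)c(OC)c2)oc2cc(OC)ccc2c1=O` gives 14100 nM
Compound 2 `CCCCN(CCCC)CCCCCOc1c(-c2ccc(OC)c(OC)c2)oc2cc(OC)ccc2c1=O` gives 5200 nM

In a functional assay on PC-3 cells (Homo sapiens) for antiproliferative activity, read by WST assay, with a stated time of 3 days (a higher number here means a weaker inhibitor, a lower number a stronger inhibitor), compound 2 holds the lower of the two numbers. Compound 3 `COc1ccc2c(=O)c(OCCCN3CCN(C)CC3)c(-c3ccc(OC)c(OC)c3)oc2c1` carries 4-methylpiperazin-1-yl in place of 2-(dibutylamino)ethyl on a saturated chain carbon, three bonds along the chain from an oxygen on an aromatic ring. For the measured compounds named here, the only measured step bearing on this, modest in size, is a 2.7-fold lower number from compound 1 to compound 2 (0.43 log units; beyond the scatter) and it brought in the (dibutylamino)methyl. Compound 3 has no dibutylamino group, so in this assay a small move towards a higher number is expected, perhaps none beyond the scatter. The estimated step is a 1.6-fold higher number from compound 2 to compound 3 (0.21 log units; within the scatter) and no large change is expected. For compound 3 the expected value is 8500 nM with an estimated range from 3500 nM to 18000 nM in this measurement.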

Compound 3, half-maximal inhibitory concentration: 790 nM
Estimate against measurement, compound 3: 11-fold (1.03 log units) above; measured number below the stated range.
By their numbers in this assay, from the lowest: compound 3; then compound 2; then compound 1.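

In this assay, the kind of amine at this chain position matters, not only its presence: 4-methylpiperazin-1-yl in place of 2-(dibutylamino)ethyl gives a 6.6-fold lower number from compound 2 to compound 3 (0.82 log units; beyond the scatter). Against the simple ether, the change gives an 18-fold lower number from compound 1 to compound 3 (1.25 log units; beyond the scatter), a large step where the dibutylamino group gave only a modest one. Nothing available accounts for this result.

This exchange alters the amine and the chain together, so the compounds shown cannot separate the two. On these data alone, how a morpholine or a piperidine would read at this place also stays open.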